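A few compounds are considered here, and "the series" means these few. Any claim that something is new, unique, unknown or untested is made for them only; others in the source may bear on it.

Measured so far in a functional assay on HEK293 cells for agonist activity at G-protein coupled receptor 84 (Homo sapiens), read by calcium flux; on this read-out lower numbers stand for smaller maximal responses and higher numbers for larger maximal responses:

compound 1, `CCCCCCc1nc(O)cc(O)n1`: 99.7%
compound 2, `CCCCCCCc1cc(O)cc(O)n1`: 87.8%

Both measured compounds carry a straight saturated chain on a small aromatic core and both reach a large maximal response in this assay. Compound 1 gives the higher of the two numbers; compound 2 sits lower by a gap that lies beyond the usual scatter. The two differ in more than one place, so no single step can be read from that gap, and it is noted only as what the two values show.

The next compound is compound 3, `CC(C)CCCc1nc(O)cc(O)n1`. It differs from compound 1 in one place: isopropyl in place of propyl on a saturated chain carbon, three bonds along the chain from an aromatic carbon. The chain keeps its length in heavy atoms and only the branching at its end is changed. Among the compounds with values here, no measured pair isolates such a change, so the size of the step in this assay is unknown. Given that compound 1 already gives 99.7%, the expected step for compound 3 is small, either none beyond the scatter or a slight fall; a rise above compound 1 is hardly possible on this read-out. The expected step is a number 7.7 percentage points lower from compound 1 to compound 3 (within the scatter). Compound 3 is estimated at 92%, within a range from 75% to 105%.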

Compound 3, largest response reached (reported as percent of maximum), in percent of the reference or control that the assay uses: 85.6%
Estimate against measurement, compound 3: 6.4 percentage points above; measured number inside the range.
By their numbers in this assay, from the lowest: compounds 3 and 2 (each within the scatter of the next); then compound 1.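

In this assay, within the data shown here, isopropyl in place of propyl on a saturated chain carbon, three bonds along the chain from an aromatic carbon, gives a number 14.1 percentage points lower from compound 1 to compound 3 (beyond the scatter) and is the first change that can be read at a single place. With the atoms unchanged and only their joining different, the maximal response of this series responds to branching at the chain end alone, while compound 3, at 85.6%, still reaches a large response in this read-out. No measurement on hand accounts for this step, so it stands as an observation only.

One step at one place cannot show whether a bulkier end would lower the response further, or whether the change would give a step of similar size on the longer chain of compound 2. Going by these compounds, how a cyclohexyl group, a longer chain, an amine or a carboxylic acid at the end of the chain would fare in this assay also stays open.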